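Urea to amide on a shared core: an untested step

This account rests on a few compounds, and the source may have more. Where it says the series, first, only, none or still open, it means among the compounds named here.

Going by the values given here, compound 2 `COc1cc(Cl)cc(-c2nn(-c3cccc(NC(=O)Nc4ccc(Cl)c(Cl)c4)c3)cc2-c2ccncc2)c1` stands highest of the two numbers so far. In a functional assay on SF-295 cells (Homo sapiens) for inhibition, read by sulforhodamine B assay, with a stated time of 48 h, tested at 10 uM (on this read-out higher numbers stand for a weaker effect at the one concentration tested and lower numbers for a stronger effect), compound 2 gives -2.42%. Compound 1 `COc1cc(Cl)cc(-c2nn(-c3cccc(NC(=O)Nc4ccc(Cl)c(C(F)(F)F)c4)c3)cc2-c2ccncc2)c1` is its nearest neighbour; in this assay compound 1 gives -7.48%. Among the compounds with values here, the one measured step, a number 5.1 percentage points higher from compound 1 to compound 2 (within the scatter), does not reach beyond the scatter. Compound 3 `COc1cc(Cl)cc(-c2nn(-c3cccc(NC(=O)c4cccc(C(F)(F)F)c4)c3)cc2-c2ccncc2)c1` is not yet measured. The change from compound 2 to compound 3 is 3-(trifluoromethyl)phenyl in place of (3,4-dichlorophenyl)amino on a carbonyl carbon. Within the data shown here, this is a different kind of change from the one between compound 1 and compound 2, which only swapped a substituent on a ring; no measured step bears directly on it. With both measured numbers close together, the expectation for compound 3 is a step of a number 4.4 percentage points higher from compound 2 to compound 3 (within the scatter), with no direction beyond the scatter supported by the data. Compound 3 is therefore estimated at 2%, within a range from -25% to 30%.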

Compound 3, a percentage reported as activity, at one concentration (the size of the read-out at that concentration, not a potency): 37.9%
Beside the measured number, compound 3's estimate is 35.9 percentage points below it; the measured number lies above the stated range.
By their numbers in this assay, from the lowest: compounds 1 and 2 (each within the scatter of the next); then compound 3.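

In this assay, putting 3-(trifluoromethyl)phenyl on the carbonyl carbon in place of (3,4-dichlorophenyl)amino turns the urea into an amide and gives a number 40.3 percentage points higher from compound 2 to compound 3 (beyond the scatter), while the same kind of change from (4-chloro-3-(trifluoromethyl)phenyl)amino gives a number 45.4 percentage points higher from compound 1 to compound 3 (beyond the scatter). This link position therefore matters far more than the ring substituent swap, which gave only a number 5.1 percentage points higher from compound 1 to compound 2 (within the scatter), and compound 3 has the weakest effect of the three at the one concentration tested. No measurement shown here gives a cause for these large steps.

The change removes the amino nitrogen and also alters the substituents on the ring, so the compounds shown cannot tell which of the two carries the step. On these data alone, a 3,4-dichlorobenzamide on the shared core would separate them, and a sulfonamide or a methylene link in this place remains open.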